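The source may hold more compounds than are shown below. What is called first, only, known or untested is meant among the compounds shown, and "the series" means these compounds.

Measured so far in a physicochemical assay for lipophilicity, read by HPLC; on this read-out higher numbers stand for higher lipophilicity and lower numbers for lower lipophilicity:
Compound 1 `C[C@@H]1CN(c2nc(-c3cnn(C)c3)ncc2C#N)CCN1C(=O)C1CC1` gives 1.5.
Compound 2 `Cn1cc(-c2ncc(C#N)c(N3C[C@@H]4C[C@H]3CN4CC3CC3)n2)cn1` gives 1.5.
Compound 3 `N#Cc1cnc(-c2cccnc2)nc1N1C[C@@H]2C[C@H]1CN2c1cccc(F)c1` gives 3.43.

Compound 1 and compound 2 stand level on this assay, and together they are the lowest of the three numbers; compound 3 sits higher, by a gap beyond the usual scatter. Compound 4 `C[C@@H]1CN(c2nc(-c3cnn(C)c3)ncc2C#N)CCN1C(=O)C1CCC1` differs from compound 1 in one place: cyclobutyl in place of cyclopropyl on a carbonyl carbon. For the measured compounds named here, no pair of measured compounds shows this same change, so its size cannot be read from the data. The expectation is a small rise in this assay, just beyond the scatter. Compound 4 is expected to give 1.9, within a range from 1.5 to 2.3. That estimate means an expected step of a number 0.40 log units higher from compound 1 to compound 4 (beyond the scatter).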

Compound 4, distribution coefficient: 2
The estimate for compound 4 lay 0.10 log units below the measured number; measured number inside the range.
By their numbers in this assay, from the lowest: compounds 1 and 2 (each within the scatter of the next); then compound 4; then compound 3.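

For the compounds shown here, replacing cyclopropyl with cyclobutyl on a carbonyl carbon gives a number 0.50 log units higher from compound 1 to compound 4 (beyond the scatter) in this assay and is the only one-place comparison in this set. The earlier compounds shown here could not show it, but this position clearly registers a change from a three-membered to a four-membered carbon ring. No supporting data explain the step.

Still open, going by these compounds, is how cyclopentyl, phenyl or a dimethylamino group would read on the same carbonyl carbon. On these data alone, whether this swap gives a similar step on another core also remains open.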